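Methylating the Amide Nitrogen of a Substance-P Receptor Ligand

A few compounds are considered here, and "the series" means these few. Any claim that something is new, unique, unknown or untested is made for them only; others in the source may bear on it.

Of the compounds shown here, three sharing a related core have been measured in an assay on IM-9 cells for binding affinity to Substance-P receptor (Homo sapiens); a higher number here means a weaker inhibitor, a lower number a stronger inhibitor. Compound 1, `COc1ccccc1CNC(=O)c1c(-c2ccccc2C)c2ccccc2c(=O)n1C`, stands at the weak end: in this assay compound 1 gives 470 nM, the highest of the three numbers. Compound 3, `CN(Cc1ccccc1)C(=O)Nc1c(-c2ccccc2)c2ccccc2c(=O)n1C`, gives 110 nM, a number lower than that of compound 1 by a margin beyond the usual scatter. Compound 2, `Cc1cc2c(-c3ccccc3)c(NC(=O)N(C)Cc3cc(C(F)(F)F)cc(C(F)(F)F)c3)n(C)c(=O)c2cc1C`, is further away still, giving 54 nM.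

The next step leads from compound 1 to compound 4, `COc1ccccc1CN(C)C(=O)c1c(-c2ccccc2C)c2ccccc2c(=O)n1C`. The change is a single one: methyl in place of hydrogen on an amide-type nitrogen. Going by the values given here, compound 2 and compound 3, the two stronger inhibitors, both carry a methyl on an amide-type nitrogen, whereas compound 1 carries hydrogen there, though no single-point step between any of these pairs has been measured.

On that basis a modest gain is expected for compound 4, with a step of a 2.4-fold lower number from compound 1 to compound 4 (0.37 log units; beyond the scatter) that should exceed the scatter but not by much. Compound 4 is estimated to give 200 nM, within a range of 80 nM to 600 nM.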

Compound 4, half-maximal inhibitory concentration: 16 nM
The estimate for compound 4 lay 13-fold (1.10 log units) above the measured number; the whole stated range lies above it.
By their numbers in this assay, from the lowest: compound 4; then compound 2; then compound 3; then compound 1.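

In this assay, methyl in place of hydrogen on the amide-type nitrogen gives a 29-fold lower number from compound 1 to compound 4 (1.47 log units; beyond the scatter), a large step from a single added carbon, so this position strongly affects the number. Going by these compounds alone, the earlier compounds offered no single-point step, and only a loose parallel in the methyl that compound 2 and compound 3 carry on an amide-type nitrogen; this pair gives the first direct reading of the change, and it holds for this pair alone. Nothing available explains why the step is so large.

From the compounds shown here alone, whether an ethyl group or a longer chain on this nitrogen would lower the number further or raise it again remains open. Also open, going by these compounds, is whether hydrogen in place of methyl on the amide-type nitrogen of compound 2 or compound 3 would cost as much.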